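Phenyl to nitro in a series at the limit

The compounds below may be only part of what the source reports. "The series", "measured", "known", "first", "only" and "open" are said of these compounds alone.

In a functional assay on HCT-116 cells (Homo sapiens) for cytotoxicity, read by MTT assay (on this read-out higher numbers stand for weaker inhibition and lower numbers for stronger inhibition), the series begins with compound 1 `Cc1cc(O)c(C(=O)/C=C/c2ccccc2)c(=O)o1` and compound 2 `Cc1cc(O)c(C(=O)/C=C/c2ccc(-c3ccccc3)cc2)c(=O)o1`. Compound 1 gives > 100000 nM, a limit of the assay and not a number. Compound 2 gives > 100000 nM, again a limit. Compound 2 therefore has no numerical position and shares its place with the only other result: the limit of > 100000 nM in this assay, at which 2 of the 2 values shown sit.

Compound 3 `Cc1cc(O)c(C(=O)/C=C/c2ccc([N+](=O)[O-])cc2)c(=O)o1` carries nitro in place of phenyl on an aromatic carbon, para to a large group: nitro in place of phenyl on an aromatic carbon. For the measured compounds named here, the one measured step, a step that the two limits leave unreadable from compound 1 to compound 2, has no readable size and gives no measure for this change. Going by the values given here, no measured step covers nitro at this place. The expectation therefore starts from compound 2 at > 100000 nM, and no shift beyond the scatter is expected in this assay. The estimated step, a number no higher from compound 2 to compound 3 (the limit leaves the size open), reflects that starting point and carries wide uncertainty. For compound 3 the estimate is 100000 nM, with an expected range of 30000 nM to 300000 nM, and another report as a limit is likely.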

Compound 3, half-maximal inhibitory concentration: 65000 nM
Compound 3: middle estimate off by 1.5-fold (0.19 log units), on the high side, and the stated range covers the measured number.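

Nitro on this aromatic carbon, para to a large group, is the first group in the series to give a reading in this assay that is a number and not a limit, while hydrogen and phenyl at the same place both stay at the limit: the limit of > 100000 nM in this assay, at which 2 of the 3 values shown sit.

Set against phenyl, the change gives an at least 1.5-fold lower number from compound 2 to compound 3 (0.18 log units; that floor lies within the scatter), and set against hydrogen, it gives an at least 1.5-fold lower number from compound 1 to compound 3 (0.18 log units; that floor lies within the scatter). On these data alone, both floors lie within the scatter, so the series still shows no step beyond it, the true sizes stay open behind the limits, and the step from hydrogen to phenyl cannot be read.

As far as these compounds go, it remains open whether a measurable reading at this place is particular to nitro or would also appear with an amine, a carboxylic acid or a methoxy group on the same aromatic carbon. Also open, from the compounds shown here alone, is whether changes elsewhere on the shared core, such as a longer chain in place of its methyl group, would bring compound 3 or its neighbours further from the limit.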